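Swapping Cyano for Methoxy on a Weaker Core

The compounds below may be only part of what the source reports. "The series", "measured", "known", "first", "only" and "open" are said of these compounds alone.

Compound 1 `COc1cc(N2CC[C@H]3CN[C@H]3C2)cnc1Br`: 21 nM
Compound 2 `N#Cc1cc(N2CC[C@H]3CN[C@H]3C2)cnc1Br`: 6.1 nM
Compound 3 `N#Cc1cncc(N2C[C@@H]3CCNC[C@@H]32)c1`: 2190 nM

In a functional assay on HEK293 cells for agonist activity at Neuronal acetylcholine receptor; alpha4/beta2 (Homo sapiens), read by FLIPR (on this read-out higher numbers stand for an effect only at larger amounts of compound and lower numbers for an effect already at smaller amounts), compound 2 gives 6.1 nM, while compound 1 gives 21 nM. The change between them is methoxy in place of cyano on an aromatic carbon, and it made a step of a 3.4-fold higher number from compound 2 to compound 1 (0.54 log units; beyond the scatter). Compound 3 has a different core and gives 2190 nM; how the two cores differ is not broken down here. Compound 4 `COc1cncc(N2C[C@@H]3CCNC[C@@H]32)c1` has not yet been measured. It differs from compound 3 by methoxy in place of cyano on an aromatic carbon. This is the same kind of change as before, not the same: in compound 2 the place is also ortho to a bromo group, which compound 3 lacks. For compound 4 a step of a 2.7-fold higher number from compound 3 to compound 4 (0.44 log units; beyond the scatter) is expected, beside the earlier step, resting on a 3.4-fold higher number from compound 2 to compound 1 (0.54 log units; beyond the scatter). Compound 4 is estimated at 6000 nM, expected between 2000 nM and 20000 nM.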

Compound 4, half-maximal effective concentration: 7690 nM
Compound 4: the middle estimate sits 1.3-fold (0.11 log units) below what was measured, and the stated range covers the measured number.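

Swapping cyano for methoxy gives a 3.5-fold higher number from compound 3 to compound 4 (0.55 log units; beyond the scatter) in this assay. The size of the step therefore carried over from one core to the other, even though compound 3 and compound 4 lack the bromo group of compound 1 and compound 2: the same change on two cores in this assay, a 3.4-fold higher number (0.54 log units; beyond the scatter) from compound 2 to compound 1 and a 3.5-fold higher number (0.55 log units; beyond the scatter) from compound 3 to compound 4, 1.0-fold (0.01 log units) apart, within the scatter of two such steps. Within the data shown here, still, this rests on only two pairs, so it does not show that the step would hold on a further core or for other groups, nor does it explain why the step has this size.

As far as these compounds go, it remains open whether another group at that place, such as an amine or a carboxylic acid, would give a lower or higher number than cyano and methoxy. Also open, from the compounds shown here alone, is how much of the gap between the two series comes from the bromo group and how much from the rest of the core.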